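A few compounds are considered here, and "the series" means these few. Any claim that something is new, unique, unknown or untested is made for them only; others in the source may bear on it.

Measured compounds:
compound 1 `COc1cccc(CN2C(=O)CN(C(=O)c3cc4cc(OC)ccc4[nH]3)C[C@@H]2COCc2ccccc2)c1`, 11700 nM
compound 2 `COc1ccc2[nH]c(C(=O)N3CC(=O)N(Cc4ccccc4)[C@@H](COCc4ccccc4)C3)cc2c1`, 8800 nM
compound 3 `Cc1ccc2[nH]c(C(=O)N3CC(=O)N(Cc4ccccc4)[C@@H](CN4CCC5(CCC5)CC4)C3)cc2c1`, 12300 nM

All three were measured in a physicochemical assay for solubility, read by spectrophotometry, in phosphate buffer, with a stated time of 2 h, at pH 7.4; on this read-out higher numbers stand for higher solubility and lower numbers for lower solubility. Compound 2 sits at the low end of these three numbers, yet the three cannot really be told apart. The step of a 1.3-fold lower number from compound 1 to compound 2 (0.12 log units; within the scatter) lies within the scatter. The gap from compound 2 to compound 3 lies within the scatter as well. Compound 4 `COc1ccc2[nH]c(C(=O)N3CC(=O)N(Cc4ccccc4)[C@@H](CN4CCN(c5ccccn5)CC4)C3)cc2c1` is the next compound; compared with compound 2 it differs in one place: 4-(pyridin-2-yl)piperazin-1-yl in place of benzyloxy on a saturated chain carbon bound to a saturated ring carbon. Within the data shown here, no measured step makes this same exchange; the only measured step concerns a methoxy and a hydrogen, and it was within the scatter. Compound 3 also carries a changed group on the same saturated chain carbon, and its number stays within the scatter of that of compound 2. Compound 4 is therefore expected to move by a 1.6-fold higher number from compound 2 to compound 4 (0.20 log units; within the scatter), a small rise that may not exceed the scatter. The estimate for compound 4 is 14000 nM, with a range from 5000 nM to 40000 nM.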

Compound 4, solubility: 30200 nM
The estimate for compound 4 lay 2.2-fold (0.33 log units) below the measured number; the measured number falls inside the stated range.
By their numbers in this assay, from the lowest: compounds 2, 1 and 3 (each within the scatter of the next); then compound 4.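

Among these compounds, on the saturated chain carbon bound to a saturated ring carbon, putting 4-(pyridin-2-yl)piperazin-1-yl in place of benzyloxy gives the first step beyond the scatter in this assay, a 3.4-fold higher number from compound 2 to compound 4 (0.54 log units; beyond the scatter), and it is a modest one. Among the compounds shown here, the only earlier step, a methoxy and hydrogen exchange on an aromatic carbon, stayed within the scatter. Nothing available explains this rise.

On these data alone, the pyridine and piperazine rings enter together, so which of them matters stays open. A piperazine without the pyridine ring, or a morpholine, on the same chain carbon would be the comparison to see.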